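Glycolamide to glycinamide: an amino swap on compound 2

The source may report more compounds than this note shows. Statements on the series, on what has been measured and on what is new or still open speak of the compounds shown alone.

Measured in a functional assay on A549 cells (Homo sapiens) for antiproliferative activity, read by MTT assay, with a stated time of 48 h; a lower number here means a stronger inhibitor, a higher number a weaker inhibitor:
- compound 1 (`COc1ccc(C(=O)c2cc(OC)c(OC)c(OC)c2)c(NC(=O)CO)c1`): (70 nM)
- compound 2 (`C=C(c1ccc(OC)cc1NC(=O)CO)c1ccc(OC)c2c1C=CC(C)(C)O2`): (70 nM)

Compound 1 and compound 2 stand level at (70 nM). The next compound, compound 3 (`C=C(c1ccc(OC)cc1NC(=O)CN)c1ccc(OC)c2c1C=CC(C)(C)O2`), keeps the core of compound 2 and carries amino in place of hydroxy on a saturated chain carbon bound to a carbonyl carbon. Within the data shown here, no measured pair shows this change, so nothing here gives its size directly, and no step beyond the scatter is expected in this assay. The estimated step is small (a 1.2-fold lower number from compound 2 to compound 3 (0.07 log units; within the scatter)). For compound 3 the expected value is (60 nM), with an estimated range from 15 nM to 250 nM.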

Compound 3, half-maximal inhibitory concentration: 90 nM
Beside the measured number, compound 3's estimate is 1.5-fold (0.18 log units) below it; measured number inside the range.
By their numbers in this assay, from the lowest: compounds 1, 2 and 3 (each within the scatter of the next).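

In this assay, among these compounds, the exchange of hydroxy for amino on a saturated chain carbon bound to a carbonyl carbon gives the first single-change step (a 1.3-fold higher number from compound 2 to compound 3 (0.11 log units; within the scatter)). This position therefore takes either group on the core of compound 2 with no step beyond the scatter. Nothing available explains this result.

From the compounds shown here alone, it remains open how a carboxylic acid, a dimethylamino group or a longer chain would read at this position. Going by these compounds, the same exchange on the core of compound 1 also remains open.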